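Swapping a cyclopropyl ketone for a bromophenyl ketone

The compounds below may be only part of what the source reports. "The series", "measured", "known", "first", "only" and "open" are said of these compounds alone.

Measured compounds:
- Compound 1 `COc1cc(-c2nnc3n2NC(c2ccco2)C(C(=O)C2CC2)S3)cc(OC)c1OC`: in a functional assay on HepG2 cells (Homo sapiens) for cytotoxicity, read by MTT assay, with a stated time of 48 h (on this read-out higher numbers stand for weaker inhibition and lower numbers for stronger inhibition), compound 1 gives > 100000 nM.
- Compound 2 `COc1cc(-c2nnc3n2NC(c2cccs2)C(C(=O)c2ccc(F)cc2)S3)cc(OC)c1OC`: compound 2 gives 54200 nM.
- Compound 3 `COc1ccc(C(=O)C2Sc3nnc(-c4cc(OC)c(OC)c(OC)c4)n3NC2c2cccs2)cc1`: compound 3 gives 68000 nM.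

For the measured compounds named here, the value for compound 1 is a limit of the assay, not a number, and it is the one value of the three that sits at that limit (the limit of > 100000 nM in this assay, at which 1 of the 3 values shown sits). Going by the values given here, compounds 2 and 3 carry aryl ketones and both give measured numbers; their one-place difference, a 1.3-fold higher number from compound 2 to compound 3 (0.10 log units; within the scatter), is the only measured step here.

The unmeasured compound 4 `COc1cc(-c2nnc3n2NC(c2ccco2)C(C(=O)c2cccc(Br)c2)S3)cc(OC)c1OC` differs from compound 1 by 3-bromophenyl in place of cyclopropyl on a carbonyl carbon. Among the compounds with values here, no measured step covers this change: the one step known concerns methoxy in place of fluoro on an aromatic carbon, not an aryl in place of a cyclopropyl on the carbonyl. What the numbers do show is that the two aryl ketones, compounds 2 and 3, give measured values while the cyclopropyl ketone, compound 1, gives only a limit. Compound 4 is therefore expected to land near the aryl ketones, at an estimated 70000 nM (range 30000 nM to 150000 nM). Since compound 1 has only a limit, the expected step of an at least 1.4-fold lower number from compound 1 to compound 4 (0.15 log units; that floor lies within the scatter) cannot be sized firmly and may again end at the limit.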

Compound 4, half-maximal inhibitory concentration: > 100000 nM
Compound 4: no number, only a limit (the forecaster's own chance of this, stated with the estimate: 40%); at least 1.4-fold (0.15 log units) between middle value and limit.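

Compound 4, like compound 1, gives only a limit of the assay and not a number, so no step can be read for 3-bromophenyl in place of cyclopropyl on the carbonyl carbon: the limit of > 100000 nM in this assay, at which 2 of the 4 values shown sit.

The compounds shown leave open how far past that limit compound 1 and compound 4 lie in this assay, and whether this swap changes the read-out at all.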